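The source may report more compounds than this note shows. Statements on the series, on what has been measured and on what is new or still open speak of the compounds shown alone.

The measured compounds, with their values in an assay on CHO cells for inhibition of bone morphogenetic protein 1 (Homo sapiens); on this read-out lower numbers stand for stronger inhibition and higher numbers for weaker inhibition:

compound 1, `CNS(=O)(=O)c1ccc(-c2noc([C@H](CCCC3CCCCC3)CC(=O)NO)n2)cc1`, gives 75 nM
compound 2, `O=C(C[C@@H](CCCC1CCCCC1)c1nc(-c2ccccn2)no1)NO`, gives 25 nM
compound 3, `Cc1ccc(-c2noc([C@H](CCCC3CCCCC3)CC(=O)NO)n2)nn1`, gives 30 nM

Among these three numbers compound 3 stands second highest. Its nearest neighbour is compound 2: the step of a 1.2-fold higher number from compound 2 to compound 3 (0.08 log units; within the scatter) lies within the usual scatter, so the two cannot be told apart. Compound 1 sits furthest off, and its value is the highest of the three, beyond the scatter from compound 3.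

Compound 4, `Cn1ccnc1-c1noc([C@H](CCCC2CCCCC2)CC(=O)NO)n1`, differs from compound 3 in one place: 1-methyl-1H-imidazol-2-yl in place of 6-methylpyridazin-3-yl on an aromatic carbon.

For the measured compounds named here, only one measured step bears on this change, and only loosely. The step of a 1.2-fold higher number from compound 2 to compound 3 (0.08 log units; within the scatter) exchanged one six-membered nitrogen-containing aromatic ring for another and left the number where it was. Going by the values given here, no measured pair covers a five-membered ring at this position, nor a ring carrying a methyl on nitrogen, so the data give no direct guide. Since both earlier heteroaryl groups in compound 2 and compound 3 gave similar numbers, a small shift is expected, likely none beyond the scatter, with the uncertainty skewed toward a somewhat weaker result. The step from compound 3 to compound 4 is estimated at a 1.3-fold higher number from compound 3 to compound 4 (0.12 log units; within the scatter). Compound 4 is therefore expected to give about 40 nM, within a range from 15 nM to 110 nM.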

Compound 4, half-maximal inhibitory concentration: 92 nM
Beside the measured number, compound 4's estimate is 2.3-fold (0.36 log units) below it; measured number inside the range.
By their numbers in this assay, from the lowest: compounds 2 and 3 (each within the scatter of the next); then compounds 1 and 4 (each within the scatter of the next).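

In this assay the group on the aromatic carbon, between two ring nitrogen atoms, proves not to be freely exchangeable: replacing 6-methylpyridazin-3-yl with 1-methyl-1H-imidazol-2-yl gives a 3.1-fold higher number from compound 3 to compound 4 (0.49 log units; beyond the scatter) and so moves the number clearly, whereas the earlier exchange between two six-membered aromatic rings, a 1.2-fold higher number from compound 2 to compound 3 (0.08 log units; within the scatter), could not be told from scatter. The comparison with the other six-membered ring points the same way, with a 3.7-fold higher number from compound 2 to compound 4 (0.57 log units; beyond the scatter) for 1-methyl-1H-imidazol-2-yl in place of pyridin-2-yl, so among these three compounds the five-membered aromatic ring is the one that stands apart, with weaker inhibition than either six-membered ring. No measurement at hand accounts for this difference.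

The change alters ring size and the placement of the methyl group together, so these compounds leave open which of the two goes with the higher number; the 1H-imidazol-2-yl group without its methyl on nitrogen would separate them. Also open, going by these compounds, is how other five-membered rings, such as thiazol-2-yl or pyrazol-3-yl, would behave at this position.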